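A few compounds are considered here, and "the series" means these few. Any claim that something is new, unique, unknown or untested is made for them only; others in the source may bear on it.

Working notes on the series.

Three compounds share the core of compound 1, `CC1(C)C(=O)N(c2ccc(Cl)cc2Cl)c2ncccc21`, which in a functional assay on the whole organism (Pleural cavity) for inhibition, with Rattus norvegicus as the target, at a dose of 25 mg/kg (a lower number here means less inhibition, a higher number more inhibition at the dose given (going by the name of the read-out)), gives 16%. Compound 3, `CC1(C)C(=O)N(c2ccc(S(C)(=O)=O)cc2)c2ncccc21`, gives 42% in this assay. Compound 2, `CC1(Sc2ccccc2)C(=O)N(c2ccccc2)c2ncccc21`, gives 0% in this assay and stands lowest of the three numbers: compound 1 lies above it and compound 3 further above it, both gaps beyond the scatter. For the measured compounds named here, no pair among the measured compounds differs in only one place, so no single step can be read from them.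

The next compound, compound 4, `CC1(Cc2ccccc2)C(=O)N(c2ccccc2)c2ncccc21`, differs from compound 2 in one place: benzyl in place of phenylsulfanyl on a saturated ring carbon. The change keeps the ring and the number of heavy atoms and removes the one hydrogen-bond acceptor. Nothing in the measured set shows what this exchange does. The expected step from compound 2 to compound 4 in this assay, a number 10 percentage points higher from compound 2 to compound 4 (within the scatter), is small and upward, if anything, and may lie within the scatter. For compound 4 the estimate in this assay is 10%, with a range from 0% to 30%.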

Compound 4, a percentage reported as inhibition, in the whole organism at one dose (the size of the read-out at that dose, not a potency): 9%
Beside the measured number, compound 4's estimate is 1 percentage points above it, and the stated range covers the measured number.
By their numbers in this assay, from the lowest: compounds 2, 4 and 1 (each within the scatter of the next, the first and the last beyond it); then compound 3.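

In this assay, for the compounds shown here, benzyl in place of phenylsulfanyl on a saturated ring carbon gives a number 9 percentage points higher from compound 2 to compound 4 (within the scatter), the first single-place step. At this position, then, the sulfur and the one hydrogen-bond acceptor of phenylsulfanyl can be exchanged for the all-carbon benzyl group, with the same heavy-atom count and aromatic ring, without separating the two compounds beyond the scatter. No measurement at hand offers an explanation for this result.

Still open, as far as these compounds go, is whether an amine or a carboxylic acid on this ring carbon, or a longer chain such as 2-phenylethyl, would give a number in this assay beyond the scatter of compound 4. Also open, from the compounds shown here alone, is whether the exchange would give a similar step with a group other than the phenyl on the ring nitrogen.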